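This account rests on a few compounds, and the source may have more. Where it says the series, first, only, none or still open, it means among the compounds named here.

The measured compounds are:

Compound 1, `CCCCCCCC(=O)NCC(C)(C)CC1=C(O)C(=O)c2ccccc2C1=O`, which in an ADME assay on Vero cells (Chlorocebus sabaeus) for cytotoxicity, read by reporter gene assay, with a stated time of 4 days (a lower number here means a stronger inhibitor, a higher number a weaker inhibitor), gives 18400 nM.
Compound 2, `CCCCCCC(C)C(=O)NCC(C)(C)CC1=C(O)C(=O)c2ccccc2C1=O`, which in this assay gives 15500 nM.
Compound 3, `CCCCCCCC(=O)OCC(C)(C)CC1=C(O)C(=O)c2ccccc2C1=O`, which in this assay gives > 258000 nM, a limit of the assay rather than a number.

Compound 1 and compound 2 differ by methyl in place of hydrogen on a saturated chain carbon bound to a carbonyl carbon and a saturated chain carbon, and the step is a 1.2-fold lower number from compound 1 to compound 2 (0.07 log units; within the scatter). Compound 3 sits at the limit of > 258000 nM in this assay, at which 1 of the 3 values shown sits, so nothing more than that can be said of where it stands. How the core of compound 3 differs from the core of compound 1 is not broken down here.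

Compound 4, `CCCCCCC(C)C(=O)OCC(C)(C)CC1=C(O)C(=O)c2ccccc2C1=O`, has not yet been measured in this assay. It relates to compound 3 by methyl in place of hydrogen on a saturated chain carbon bound to a carbonyl carbon and a saturated chain carbon, the same change as made from compound 1 to compound 2, at the same place. Because that earlier step was a 1.2-fold lower number from compound 1 to compound 2 (0.07 log units; within the scatter), the change is expected to move compound 4 little from compound 3, so that compound 4 is expected to remain at the assay limit, giving an estimated step that the limit leaves unreadable from compound 3 to compound 4. Compound 4 is therefore estimated at 300000 nM, between 150000 nM and 600000 nM.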

Compound 4, half-maximal inhibitory concentration: 450 nM
Compound 4: middle estimate off by 670-fold (2.82 log units), on the high side; the measured number lies below the stated range.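

In this assay, the change from heptyl to 1-methylheptyl on the core of compound 3 gives an at least 570-fold lower number from compound 3 to compound 4 (2.75 log units; beyond the scatter), so the effect seen on the core of compound 1 does not carry over to this second core: the same change on two cores in this assay, a 1.2-fold lower number (0.07 log units; within the scatter) from compound 1 to compound 2 and an at least 570-fold lower number (2.75 log units; beyond the scatter) from compound 3 to compound 4, at least 480-fold (2.68 log units) apart, beyond the scatter of two such steps

The value of compound 3, > 258000 nM, is a limit of the assay and not a number, so this step has only a lower bound on its size. The two pairs show that, in this series, the size of the step from this methyl change cannot be transferred from one of these cores to the other, but they do not show why the two steps differ or how the change would behave on any further core.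

The compounds shown leave open whether an ethyl group in place of the methyl, or a longer chain, would give a similar gap between the two cores. They also leave open how the same change would read on a core carrying a thioester or an amine.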